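The source may report more compounds than this note shows. Statements on the series, on what has been measured and on what is new or still open speak of the compounds shown alone.

Measured compounds:
compound 1 `COc1ccc(C(=O)O)cc1OCCCCOc1ccc(C(=O)C(C)C)c(O)c1C` — in an assay on HEK293 cells for positive allosteric modulation of metabotropic glutamate receptor 2 (Rattus norvegicus), read by thallium flux, with a stated time of 2.5 min (a higher number here means a larger maximal response, a lower number a smaller maximal response), compound 1 reaches 66.6%
compound 2 `COc1ccc(C(=O)O)cc1OCCCCOc1ccc(C(C)=O)c(O)c1C` — compound 2 reaches 70.7%
compound 3 `Cc1c(OCCCCOc2ccc(F)c(C(=O)O)c2)ccc(C(=O)C(C)C)c1O` — compound 3 reaches 74.1%

Within this set, one change occurs twice. Compound 1 and compound 2 differ by methyl in place of isopropyl on a carbonyl carbon, and this gives a number 4.1 percentage points higher from compound 1 to compound 2 (within the scatter). The core of compound 3 differs from the core of compound 1 in more than one place; that difference is not broken down here. Compound 4 `CC(=O)c1ccc(OCCCCOc2ccc(F)c(C(=O)O)c2)c(C)c1O` carries the same change relative to compound 3, namely (methyl in place of isopropyl on a carbonyl carbon), at a place described in identical words to the earlier case, so it is taken as the same change. The step expected here is a number 2.9 percentage points higher from compound 3 to compound 4 (within the scatter), resting on the earlier step of a number 4.1 percentage points higher from compound 1 to compound 2 (within the scatter), which lay within the scatter. Compound 4 is therefore expected to reach about 77%. For compound 4 the estimated range runs from 66% to 88%.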

Compound 4, largest response reached (reported as percent of maximum), in percent of the reference or control that the assay uses: 75.5%
Compound 4: middle estimate off by 1.5 percentage points, on the high side; low and high end bracket the measured number.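

In this assay, methyl in place of isopropyl on a carbonyl carbon gives a number 1.4 percentage points higher from compound 3 to compound 4 (within the scatter). Set beside the earlier case on the other core, the two steps do not differ: the same change on two cores in this assay, a number 4.1 percentage points higher (within the scatter) from compound 1 to compound 2 and a number 1.4 percentage points higher (within the scatter) from compound 3 to compound 4, 2.7 percentage points apart, within the scatter of two such steps This shows that isopropylcarbonyl to acetyl carries between these two cores without a detectable difference in the step, but it does not show that the change itself alters the maximal response, nor that it would behave alike on any further core.

Still open, as far as these compounds go, is how the response would read with a cyclopropyl or phenyl group on that carbonyl carbon. Also open, from the compounds shown here alone, is the effect of a tetrazole in place of the carboxylic acid.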